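Extending Compound 1 with an Aminopyrazole Substituent

A few compounds are considered here, and "the series" means these few. Any claim that something is new, unique, unknown or untested is made for them only; others in the source may bear on it.

Compound 1 `C[C@@H]1CCCN1c1c(C#N)c2c(N)ncnc2n1C` gives 0.4 nM in an assay on isolated protein for binding affinity to Leucine-rich repeat serine/threonine-protein kinase 2 (Homo sapiens), read by TR-FRET and LanthaScreen, with a stated time of 2 h (on this read-out higher numbers stand for weaker inhibition and lower numbers for stronger inhibition), the lowest of the two numbers recorded so far; its nearest neighbour, compound 2 `Cn1c(N)c(C#N)c2c(N)ncnc21`, gives 346 nM in this assay. Among the measured compounds shown here, the single measured step, an 870-fold higher number from compound 1 to compound 2 (2.94 log units; beyond the scatter), concerns an amino group taking the place of the 2-methylpyrrolidin-1-yl group and leaves the rest of the shared core untouched. Compound 3 `Cc1nn(C)cc1Nc1nc(N)c2c(C#N)c(N3CCC[C@H]3C)n(C)c2n1` differs from compound 1 at another position: (1,3-dimethyl-1H-pyrazol-4-yl)amino in place of hydrogen on an aromatic carbon. The new group enters on an aromatic carbon of the six-membered ring, between two ring nitrogen atoms, while the 2-methylpyrrolidin-1-yl group of compound 1 is retained. For the measured compounds named here, no measured step touches this position, so the change from compound 1 to compound 2 gives no direct guide beyond showing that compound 1 sits at the strong end of the pair. The expected step is a 1.3-fold higher number from compound 1 to compound 3 (0.10 log units; within the scatter), which may well lie within the scatter. Compound 3 is estimated at 0.5 nM in this assay, with a range from 0.1 nM to 3 nM.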

Compound 3, inhibition constant: 1 nM
Compound 3: the middle estimate sits 2.0-fold (0.30 log units) below what was measured, and the stated range covers the measured number.
By their numbers in this assay, from the lowest: compound 1; then compound 3; then compound 2.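

Among the compounds shown here, the aromatic carbon between two ring nitrogen atoms, untouched by the earlier compounds, proves able to carry (1,3-dimethyl-1H-pyrazol-4-yl)amino in this assay, at the price of a 2.5-fold higher number from compound 1 to compound 3 (0.40 log units; beyond the scatter). That step is modest and lies beyond the scatter, whereas replacing the 2-methylpyrrolidin-1-yl group at the other position gives an 870-fold higher number from compound 1 to compound 2 (2.94 log units; beyond the scatter), so this added group costs far less than that loss. Nothing available explains why the added group is tolerated at this carbon.

The compounds shown leave open which part of the added group accounts for the small step, and how a plain amino group or a methoxy group would read at this carbon. They also leave open whether an unsubstituted pyrazol-4-ylamino group would read the same as the dimethyl version.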